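Hydroxycyclohexyl in Place of the Methoxyimino Ring on Compound 1

A few compounds are considered here, and "the series" means these few. Any claim that something is new, unique, unknown or untested is made for them only; others in the source may bear on it.

Compound 1 `CON=C1CCC(N(c2cc(C#CC(C)(C)C)sc2C(=O)O)C(=O)[C@H]2CC[C@H](C)CC2)CC1` is one of two measured compounds. In an ADME assay for protein binding, using equilibrium dialysis, at pH 7.4, tested at 2 uM (on this read-out higher numbers stand for a larger free fraction and lower numbers for a smaller free fraction), compound 1 gives 0.07, and compound 2 `CC(C)N(c1cc(C#CC(C)(C)C)sc1C(=O)O)C(=O)[C@H]1CC[C@H](Cl)CC1` gives 0.14; the two numbers lie within the scatter of each other, so compound 1 stands together with compound 2 rather than apart from it. Compound 3 `CC(C)(C)C#Cc1cc(N(C(=O)[C@H]2CC[C@H](C)CC2)[C@H]2CC[C@H](O)CC2)c(C(=O)O)s1` differs from compound 1 by a group of 7 heavy atoms (6 carbon, 1 oxygen; one six-membered non-aromatic ring of carbon only) in place of a group of 9 heavy atoms (7 carbon, 1 nitrogen, 1 oxygen; one six-membered non-aromatic ring of carbon only), on an amide-type nitrogen. For the measured compounds named here, no step between measured compounds is available for this change. A step from compound 1 to compound 3 of a 1.3-fold higher number from compound 1 to compound 3 (0.11 log units; within the scatter) is expected, not beyond the scatter in either direction. For compound 3 an unbound fraction of 0.09 is estimated, with a range from 0.04 to 0.2.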

Compound 3, unbound fraction: 0.19
Estimate against measurement, compound 3: 2.1-fold (0.32 log units) below; low and high end bracket the measured number.
By their numbers in this assay, from the lowest: compounds 1, 2 and 3 (each within the scatter of the next, the first and the last beyond it).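

In this assay the change from the methoxyimino ring to 4-hydroxycyclohexyl on the amide-type nitrogen gives a modest step beyond the scatter (a 2.7-fold higher number from compound 1 to compound 3 (0.43 log units; beyond the scatter)). For the compounds shown here, this is the first step read at this position, and it shows that the unbound fraction responds to a change of this group. No measurement shown accounts for the step. The compounds shown leave open whether the step follows the hydroxyl or the ring without the methoxyimino group. A plain cyclohexyl or a 4-aminocyclohexyl on the same nitrogen would bear on that.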